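From isobutyl to cyclohexyl on the amide-type nitrogen

The source may hold more compounds than are shown below. What is called first, only, known or untested is meant among the compounds shown, and "the series" means these compounds.

In a functional assay on the whole organism with Mus musculus as the target (a lower number here means that less compound is needed, a higher number that more compound is needed for the effect), compound 1 (`CC(C)NC(=O)CCC(=O)c1cccc(C(F)(F)F)c1`) gives > 200 mg/kg, which is a limit and not a number. In this assay, compound 2 (`CCC(C)NC(=O)CCC(=O)c1cccc(C(F)(F)F)c1`) gives > 200 mg/kg, again a limit. In this assay, compound 3 (`CC(C)CNC(=O)CCC(=O)c1cccc(C(F)(F)F)c1`) gives > 200 mg/kg, also a limit. Among the compounds with values here, compound 3 therefore has no readable rank, and the series so far stands at the limit of > 200 mg/kg in this assay, at which 3 of the 3 values shown sit.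

The next structure is compound 4 (`O=C(CCC(=O)c1cccc(C(F)(F)F)c1)NC1CCCCC1`), which has cyclohexyl in place of isobutyl on an amide-type nitrogen.

Within the data shown here, three measured steps bear on this change, as all three alter the group on the same nitrogen or its chain. They are a step that the two limits leave unreadable from compound 1 to compound 2, a step that the two limits leave unreadable from compound 1 to compound 3 and a step that the two limits leave unreadable from compound 2 to compound 3. None of them gives a size or a direction, and none involves a ring on that nitrogen. Among the measured compounds shown here, no step of a particular size or direction can be derived for this assay, so the expectation stays close to the shared limit, with a wide range and a further limit as the likeliest report.

The estimated change is a number no higher from compound 3 to compound 4 (the limit leaves the size open). For compound 4 the expected value is 200 mg/kg, with an estimated range from 90 mg/kg to 400 mg/kg.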

Compound 4, dose for half-maximal effect: > 200 mg/kg
Compound 4 gave a limit, no number (the forecaster's own chance of this, stated with the estimate: 65%); the middle value sits exactly at the limit.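

In this assay compound 4 gives > 200 mg/kg, a limit and not a number. No step between compound 4 and compounds 1, 2 or 3 can be read, and the series stands at: the limit of > 200 mg/kg in this assay, at which 4 of the 4 values shown sit.

The compounds shown leave open whether any group on the amide-type nitrogen gives a numerical dose in this assay.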